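Swapping bromo for a pyrrolidine amide on the side ring

A few compounds are considered here, and "the series" means these few. Any claim that something is new, unique, unknown or untested is made for them only; others in the source may bear on it.

Three analogues sharing one core have been tested in a functional assay on NCI-H292 cells (Homo sapiens) for antiproliferative activity; a lower number here means a stronger inhibitor, a higher number a weaker inhibitor. Compound 3 `O=C1N/C(=C\c2ccc(O)cc2)C(=O)N1c1cccc(Br)c1` gives only a limit there, > 200000 nM, not a number. Compound 1 `O=C(O)c1cccc(N2C(=O)N/C(=C\c3ccc(O)cc3)C2=O)c1` likewise gives only the limit > 200000 nM. Compound 2 `O=C1N/C(=C\c2ccc(O)cc2)C(=O)N1c1ccc(Br)cc1` gives 69900 nM, and an at least 2.8-fold higher number from compound 2 to compound 3 (0.45 log units; beyond the scatter) lies beyond the scatter. The other step, a step that the two limits leave unreadable from compound 1 to compound 3, cannot be sized because the limit of > 200000 nM in this assay, at which 2 of the 3 values shown sit, covers both ends. Compound 4 `O=C(c1cccc(N2C(=O)N/C(=C\c3ccc(O)cc3)C2=O)c1)N1CCCC1` differs from compound 3 in one place: (pyrrolidin-1-yl)carbonyl in place of bromo on an aromatic carbon. Only the unreadable step from compound 1 touches this same aromatic carbon, and compound 1 with its carboxy group there also sits at the limit. Compound 4 is therefore expected to remain weak, the expected step being a number no higher from compound 3 to compound 4 (the limit leaves the size open). Compound 4 is estimated at 200000 nM, between 60000 nM and 500000 nM.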

Compound 4, half-maximal inhibitory concentration: > 200000 nM
Compound 4 was reported as a limit; the forecaster's own chance of this, stated with the estimate: 70%; the middle value lies on the limit itself.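

Among the compounds shown here, compound 1, compound 3 and compound 4 all give only a limit, so no step among them can be read: the limit of > 200000 nM in this assay, at which 3 of the 4 values shown sit. On these data alone, whether the carboxy, bromo and (pyrrolidin-1-yl)carbonyl groups on this aromatic carbon differ in strength stays open.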